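Chloro-dimethoxyphenyl on the Triazole: Expecting Another Weak Value

The source may hold more compounds than are shown below. What is called first, only, known or untested is meant among the compounds shown, and "the series" means these compounds.

Compound 1 `N#CC1=C(N)Oc2c(N)cc3nc4ccccc4nc3c2C12C(=O)N(Cc1cnnn1-c1ccc(Cl)cc1)c1ccccc12` — in an ADME assay on L02 cells (Homo sapiens) for antiproliferative activity, read by MTT assay, with a stated time of 48 h (a lower number here means a stronger inhibitor, a higher number a weaker inhibitor), compound 1 gives > 50000 nM, a limit of the assay.
Compound 2 `N#CC1=C(N)Oc2c(N)cc3nc4ccccc4nc3c2C12C(=O)N(Cc1cnnn1-c1ccccc1Br)c1ccccc12` — in this assay compound 2 gives 29200 nM.
Compound 3 `N#CC1=C(N)Oc2c(N)cc3nc4ccccc4nc3c2C12C(=O)N(Cc1cnnn1-c1ccc(F)c(Cl)c1)c1ccccc12` — in this assay compound 3 gives > 50000 nM, a limit of the assay.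

Compound 3 therefore stands at the limit of the assay rather than at a number, as does compound 1; this is the point noted as the limit of > 50000 nM in this assay, at which 2 of the 3 values shown sit. Only compound 2 gives a number within range. The change from compound 1 to compound 2 is an at least 1.7-fold lower number from compound 1 to compound 2 (0.23 log units; that floor lies within the scatter), and from compound 2 to compound 3 it is an at least 1.7-fold higher number from compound 2 to compound 3 (0.23 log units; that floor lies within the scatter), both steps resting on a floor that lies within the scatter. The step from compound 1 to compound 3 is a step that the two limits leave unreadable from compound 1 to compound 3. Nothing among these three values shows a readable shift with the aryl group on the triazole nitrogen.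

Compound 4 `COc1cc(-n2nncc2CN2C(=O)C3(C(C#N)=C(N)Oc4c(N)cc5nc6ccccc6nc5c43)c3ccccc32)c(OC)cc1Cl` differs from compound 3 by 4-chloro-2,5-dimethoxyphenyl in place of 3-chloro-4-fluorophenyl on an aromatic nitrogen. The measured steps that bear on this change all sit within the scatter or at the limit, so no step beyond the scatter is expected in this assay, in either direction. Compound 4 is therefore estimated at 45000 nM, within 20000 nM to 100000 nM, which means an expected step of an at least 1.1-fold lower number from compound 3 to compound 4 (0.04 log units; that floor lies within the scatter), with a fair chance that only a limit is reported again.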

Compound 4, half-maximal inhibitory concentration: > 50000 nM
Compound 4: only a limit was reported (the forecaster's own chance of this, stated with the estimate: 60%); middle value at least 1.1-fold (0.04 log units) from the limit.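

Compound 4 gives > 50000 nM in this assay, a limit of the assay, so the larger 4-chloro-2,5-dimethoxyphenyl group, which carries hydrogen-bond acceptors that 3-chloro-4-fluorophenyl lacks, does not bring a number within range here. For the compounds shown here, the only comparison that can be read is an at least 1.7-fold higher number from compound 2 to compound 4 (0.23 log units; that floor lies within the scatter), so even against compound 2, the one compound with a number, this change shows no step beyond the scatter. The steps that join compound 4 to compound 1 and to compound 3 cannot be read, and this position on the triazole nitrogen now offers very little contrast, with compound 2 the only exception to the shared result: the limit of > 50000 nM in this assay, at which 3 of the 4 values shown sit.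

Going by these compounds, how far compound 1, compound 3 and compound 4 actually lie from one another remains unknown, and so does whether the methoxy groups, the chlorine or the larger size of the entering group matter at all in this assay. On these data alone, it also stays open whether a different kind of group on this nitrogen, such as a pyridine ring, a benzyl group or a phenyl ring bearing an amine or a carboxylic acid, would give a readable value.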